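The source may hold more compounds than are shown below. What is called first, only, known or untested is meant among the compounds shown, and "the series" means these compounds.

Measured so far in an ADME assay on Vero cells (Chlorocebus sabaeus) for cytotoxicity, read by MTT assay; a higher number here means that more compound is tolerated, a lower number that less compound is tolerated:
- compound 1 `COc1ccc(-c2nc3ccccn3c2Nc2cc(OC)c(OC)c(OC)c2)cc1O`: 50000 nM
- compound 2 `COc1ccc(-c2nc3cnccn3c2Nc2cc(OC)c(OC)c(OC)c2)cc1`: 75000 nM
- compound 3 `COc1ccc(Nc2c(-c3ccc(OC)cc3)nc3ccccn23)cc1`: 54000 nM

These three values all lie within the usual scatter of one another, so compound 3, at 54000 nM, cannot be told apart from compound 1 or compound 2 in this assay.

Compound 4 `COc1ccc(Nc2c(-c3cccc(O)c3)nc3ccccn23)cc1` has 3-hydroxyphenyl in place of 4-methoxyphenyl on an aromatic carbon of the five-membered ring of the shared core (3-hydroxyphenyl in place of 4-methoxyphenyl on an aromatic carbon). For the measured compounds named here, no measured pair shows this change directly. However, compound 1, which also bears a hydroxyl on its aryl group, gives 50000 nM, so no shift beyond the scatter is expected. The expected step of a 1.1-fold lower number from compound 3 to compound 4 (0.03 log units; within the scatter) is small. For compound 4 the estimated value is 50000 nM, with an expected range of 25000 nM to 95000 nM.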

Compound 4, concentration lethal to 50% of the cells: 74000 nM
Estimate against measurement, compound 4: 1.5-fold (0.17 log units) below; low and high end bracket the measured number.
By their numbers in this assay, from the lowest: compounds 1, 3, 4 and 2 (each within the scatter of the next).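

In this assay, putting 3-hydroxyphenyl in place of 4-methoxyphenyl on this aromatic carbon of the five-membered ring gives a 1.4-fold higher number from compound 3 to compound 4 (0.14 log units; within the scatter), so compound 3 and compound 4 cannot be told apart. For the compounds shown here, this is the first pair that differs in one place, and it shows that a hydrogen-bond donor can enter here without a measurable effect on how much compound the cells tolerate. Nothing measured here offers an explanation for this result.

This swap alters both the group and where it sits on the phenyl ring, so the two contributions cannot be separated. As far as these compounds go, whether an amine or a carboxylic acid on that phenyl ring would also read the same remains open.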